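Swapping a pyridine amide for a dimethylisoxazole amide

The compounds below may be only part of what the source reports. "The series", "measured", "known", "first", "only" and "open" are said of these compounds alone.

Three amides built on one shared core have been tested in a toxicity assay on HepG2 cells (Homo sapiens) for inhibition, read by CellTiter-Glo, with a stated time of 48 h; on this read-out higher numbers stand for weaker inhibition and lower numbers for stronger inhibition. Compound 1 `COc1ccc2nc(C)cc(OCC(=O)Nc3cc(C)cc(C)c3)c2c1` gives 20000 nM in this assay. Compound 2 `COc1ccc2nc(C)cc(OCC(=O)Nc3cc(C)c(F)c(C)c3)c2c1` reaches only > 100000 nM in this assay, which is a limit of the assay and not a number. Compound 3 `COc1ccc2nc(C)cc(OCC(=O)Nc3ccccn3)c2c1` likewise reaches only > 100000 nM in this assay, again a limit rather than a number. Compound 3 therefore stands at the ceiling of what this assay reports, with no exact number attached. The step of an at least 5.0-fold higher number from compound 1 to compound 3 (0.69 log units; beyond the scatter) is the only one that reads as a change in the amide substituent, and it points toward weaker inhibition. The step that the two limits leave unreadable from compound 2 to compound 3 cannot be sized, since the limit of > 100000 nM in this assay, at which 2 of the 3 values shown sit, leaves both ends open.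

Compound 4 `COc1ccc2nc(C)cc(OCC(=O)Nc3noc(C)c3C)c2c1` differs from compound 3 by 4,5-dimethyl-1,2-oxazol-3-yl in place of pyridin-2-yl on an amide-type nitrogen. Because both earlier replacements of the aryl amide ended at the limit of > 100000 nM in this assay, at which 2 of the 3 values shown sit, the expectation is that this further heteroaryl amide stays there too. Compound 4 is expected to give about 100000 nM in this assay, within a range from 30000 nM to 300000 nM, most probably again reported as a limit. The expected step of a number no higher from compound 3 to compound 4 (the limit leaves the size open) is thus estimated to be none beyond the scatter.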

Compound 4, half-maximal inhibitory concentration: > 100000 nM
Compound 4: only a limit was reported; the forecaster's own chance of this, stated with the estimate: 70%; the middle value lies on the limit itself.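

The amide-type nitrogen now tolerates a second kind of heteroaromatic ring, since a five-membered 4,5-dimethyl-1,2-oxazol-3-yl moves the read-out the same way as the six-membered pyridin-2-yl, with an at least 5.0-fold higher number from compound 1 to compound 4 (0.69 log units; beyond the scatter) pointing to weaker inhibition in this assay. Compound 4 gives > 100000 nM, which is a limit of the assay and not a number. The steps from compound 2 to compound 4 and from compound 3 to compound 4 cannot be read, because their values are all limits: the limit of > 100000 nM in this assay, at which 3 of the 4 values shown sit.

Going by these compounds, how compound 2, compound 3 and compound 4 rank against one another therefore stays open. Also open, on these data alone, is whether a non-aromatic group on that nitrogen, such as cyclohexyl or a longer alkyl chain, would give a measurable number like that of compound 1.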